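The source may hold more compounds than are shown below. What is called first, only, known or untested is meant among the compounds shown, and "the series" means these compounds.

Of the compounds shown here, three sharing one core have been read in a physicochemical assay for solubility, read by nephelometry, in phosphate buffer, measured as kinetic solubility, with a stated time of 30 min, at pH 6.5; on this read-out higher numbers stand for higher solubility and lower numbers for lower solubility. Compound 1 `COc1cc(-c2cc(-c3ccc(S(C)(=O)=O)cc3)cnc2N)ccc1O` gives 6.3 ug/mL, compound 2 `CS(=O)(=O)c1ccc(-c2cnc(N)c(-c3ccc(CO)nc3)c2)cc1` gives 25 ug/mL, and compound 3 `CS(=O)(=O)c1ccc(-c2cnc(N)c(-c3ccc(C(F)(F)F)c(F)c3)c2)cc1` gives 1.6 ug/mL. Compound 2 therefore stands highest of the three, and its gaps to both of the others lie beyond the usual scatter of repeated measurements.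

Compound 4 `CS(=O)(=O)c1ccc(-c2cnc(N)c(-c3ccc(C#N)cc3)c2)cc1` has not yet been measured. It differs from compound 2 in one place: 4-cyanophenyl in place of 6-(hydroxymethyl)pyridin-3-yl on an aromatic carbon. Put simply, 4-cyanophenyl stands in place of 6-(hydroxymethyl)pyridin-3-yl on an aromatic carbon.

Within the data shown here, no two measured compounds differ in just one place, so the size of this step can only be judged loosely. Still, the three values offer a hint. Compound 2, at 25 ug/mL, has a ring with a nitrogen at this place. Compound 1, at 6.3 ug/mL, and compound 3, at 1.6 ug/mL, each have a ring of carbon only there, as compound 4 will, and neither goes against this small pattern. A fall beyond the scatter is therefore expected, with an estimated step of a 7.8-fold lower number from compound 2 to compound 4 (0.89 log units; beyond the scatter). For compound 4 the estimated value is 3.2 ug/mL, with an expected range from 1.2 ug/mL to 8.5 ug/mL.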

Compound 4, solubility: 1.6 ug/mL
The estimate for compound 4 lay 2.0-fold (0.30 log units) above the measured number, and the stated range covers the measured number.
By their numbers in this assay, from the lowest: compounds 3 and 4 (each within the scatter of the next); then compound 1; then compound 2.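

In this assay, the change from 6-(hydroxymethyl)pyridin-3-yl to 4-cyanophenyl gives a 16-fold lower number from compound 2 to compound 4 (1.19 log units; beyond the scatter). Among these compounds, this is the first direct comparison at this position, and with the rest of the molecule held the same, it shows that the read-out depends strongly on which group sits on this aromatic carbon, ortho to an amino group. The change alters several things at once, since the group that leaves has a ring nitrogen and a hydrogen-bond donor while the group that enters has a ring of carbon only, a nitrile and no donor, and no measurement here indicates which of these differences accounts for the step.

The compounds shown leave open how the step divides between the ring nitrogen and the two groups carried on the ring, a question that 4-(hydroxymethyl)phenyl and 6-cyanopyridin-3-yl could help to separate, as each keeps one feature of the pair while changing the other. They also leave open how groups of other kinds at this position would read, such as an aminomethyl group or a carboxylic acid on the same ring.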